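A few compounds are considered here, and "the series" means these few. Any claim that something is new, unique, unknown or untested is made for them only; others in the source may bear on it.

Of the compounds shown here, three have so far been tested in an assay on isolated protein for displacement of a labelled ligand from metabotropic glutamate receptor 5 (Homo sapiens), with a stated time of 60 min, tested at 1 uM; on this read-out higher numbers stand for more inhibition at the one concentration tested (going by the name of the read-out) and lower numbers for less inhibition. Compound 1 `Cc1cc(C)cc(S(=O)(=O)c2cnc3cc(F)ccc3c2N2CCC(C)CC2)c1` gives 80% in this assay, the second highest of the three numbers. Compound 3 `Cc1ccc2ncc(S(=O)(=O)c3ccc(Cl)c(Cl)c3)c(N3CCC(C)CC3)c2c1` gives 82%, a result within the scatter of compound 1, so the two cannot be told apart. Compound 2 `Cc1ccc(S(=O)(=O)c2cnc3ccc(Cl)cc3c2N2CCC(C)CC2)cc1F` gives 68%, a number that lies beyond the scatter under compound 1. Compound 4 `CC1CCN(c2c(S(=O)(=O)c3ccccc3)cnc3cc(F)ccc23)CC1` has not yet been measured. It differs from compound 1 in one place: phenyl in place of 3,5-dimethylphenyl on a sulfonyl sulfur. Within the data shown here, no measured pair shows what this change does, so the expectation rests on compound 1 alone. A modest drop in inhibition is expected, of the size a number 15 percentage points lower from compound 1 to compound 4 (beyond the scatter), although a result within the scatter would not surprise. Compound 4 is estimated to give 65%, between 40% and 85%.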

Compound 4, a percentage reported as inhibition, at one concentration (the size of the read-out at that concentration, not a potency): 87%
Compound 4: middle estimate off by 22 percentage points, on the low side; the measured number lies above the stated range.
By their numbers in this assay, from the lowest: compound 2; then compounds 1, 3 and 4 (each within the scatter of the next).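

Phenyl in place of 3,5-dimethylphenyl on a sulfonyl sulfur gives a number 7 percentage points higher from compound 1 to compound 4 (within the scatter) in this assay. On this core, then, the read-out at the one concentration tested does not depend on the dimethyl substitution, and the plain phenyl serves as well as the larger group. No measurement shown bears on the reason for this result.

On these data alone, what remains open is how a group without an aromatic ring on the sulfonyl sulfur, such as cyclohexyl or a short alkyl chain, would read out. As far as these compounds go, a phenyl carrying an amine is equally open.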